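The source may report more compounds than this note shows. Statements on the series, on what has been measured and on what is new or still open speak of the compounds shown alone.

Values in a functional assay on cells (T-cell line, Homo sapiens) for inhibition; on this read-out higher numbers stand for weaker inhibition and lower numbers for stronger inhibition:
- compound 1 `CN1CCC(COC(c2ccccc2)c2ccccc2)CC1`: > 20000 nM (a limit)
- compound 2 `Cc1ccc(CCCN2CCC(COC(c3ccccc3)c3ccccc3)CC2)cc1`: 200 nM
- compound 3 `CCN1CCC(COC(c2ccccc2)c2ccccc2)CC1`: > 20000 nM (a limit)

Compound 3 gives no number, only a limit: the limit of > 20000 nM in this assay, at which 2 of the 3 values shown sit. Compound 4 `CCCN1CCC(COC(c2ccccc2)c2ccccc2)CC1` differs from compound 3 by methyl in place of hydrogen on a saturated chain carbon, two bonds along the chain from an amine nitrogen in a ring, turning ethyl to propyl. Within the data shown here, the closest precedent, a step that the two limits leave unreadable from compound 1 to compound 3, gives no readable size. Large steps appear only with much bigger groups, 2-(4-methylphenyl)ethyl and 4-methylbenzyl: an at least 100-fold lower number from compound 1 to compound 2 (2.00 log units; beyond the scatter), and an at least 100-fold higher number from compound 2 to compound 3 (2.00 log units; beyond the scatter). One added methyl is far smaller than these, so no step beyond the scatter is expected in this assay, and a further limit is likely. The estimate means an expected a number no higher from compound 3 to compound 4 (the limit leaves the size open). For compound 4 the estimated value is 20000 nM, with an expected range of 8000 nM to 40000 nM.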

Compound 4, half-maximal inhibitory concentration: 17800 nM
Compound 4: middle estimate off by 1.1-fold (0.05 log units), on the high side; low and high end bracket the measured number.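

In this assay, among these compounds, ethyl to propyl gives the first actual number for a short chain on the amine nitrogen in a ring, but an at least 1.1-fold lower number from compound 3 to compound 4 (0.05 log units; that floor lies within the scatter) and an at least 1.1-fold lower number from compound 1 to compound 4 (0.05 log units; that floor lies within the scatter) are only floors. Propyl alone stays far from compound 2: an 89-fold higher number from compound 2 to compound 4 (1.95 log units; beyond the scatter), so the 4-methylphenyl end of the chain marks a large step at this position. Compounds 1 and 3 remain limits, not numbers: the limit of > 20000 nM in this assay, at which 2 of the 4 values shown sit.

Still open, going by these compounds, is whether butyl or a longer chain moves the number at all. Also open, on these data alone, is whether plain 3-phenylpropyl, without the methyl, matches compound 2.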